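A few compounds are considered here, and "the series" means these few. Any claim that something is new, unique, unknown or untested is made for them only; others in the source may bear on it.

Compounds measured so far:

- Compound 1, `O=C(O)c1ccccc1-c1ccc(CCc2ncc(CC3CCCCC3)[nH]2)cc1` — 41 nM
- Compound 2, `O=C(O)c1ccccc1-c1ccc(CCc2ncc(CC3CCC3)[nH]2)cc1` — 588 nM
- Compound 3, `N#Cc1ccc(Cc2cnc(CCc3ccc(-c4ccccc4C(=O)O)cc3)[nH]2)cc1` — 5890 nM

All three were tested in an in vitro functional assay on cells for agonist activity at Bombesin receptor subtype-3 (Homo sapiens), read by luminescence and calcium flux; a higher number here means that more compound is needed for the effect, a lower number that less compound is needed. Compound 1 gives the lowest number of the three in this assay. Compound 2 sits nearest to it, a 14-fold higher number from compound 1 to compound 2 (1.16 log units; beyond the scatter), and compound 3 sits furthest away, a 140-fold higher number from compound 1 to compound 3 (2.16 log units; beyond the scatter). Between the two weaker compounds the gap is a 10-fold higher number from compound 2 to compound 3 (1.00 log units; beyond the scatter).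

The unmeasured compound 4, `O=C(O)c1ccccc1-c1ccc(CCc2ncc(CCc3ccccc3)[nH]2)cc1`, differs from compound 1 in one place: benzyl in place of cyclohexyl on a saturated chain carbon bound to an aromatic carbon.

Two of the measured steps speak to this change. Shrinking the saturated ring, as from compound 1 to compound 2, already raised the number a great deal, and swapping the saturated ring for an aromatic one, as from compound 1 to compound 3, raised it even more. Compound 4 also carries an aromatic ring in this place, though without the nitrile and set one chain carbon further out, so the measured steps point toward a higher number than compound 1, most likely beyond the scatter but short of the step seen for compound 3.

Compound 4 is therefore expected to give roughly 450 nM in this assay, in a range from 90 nM to 2500 nM, which corresponds to an estimated step of an 11-fold higher number from compound 1 to compound 4 (1.04 log units; beyond the scatter).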

Compound 4, half-maximal effective concentration: 1320 nM
Compound 4: the middle estimate sits 2.9-fold (0.47 log units) below what was measured; the measured number falls inside the stated range.
By their numbers in this assay, from the lowest: compound 1; then compound 2; then compound 4; then compound 3.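

In this assay, phenethyl in place of cyclohexylmethyl gives a 32-fold higher number from compound 1 to compound 4 (1.51 log units; beyond the scatter), so a large rise at this position does not require a nitrile. Even so, the nitrile-free compound 4 does better than the cyano compound, with a 4.5-fold lower number from compound 3 to compound 4 (0.65 log units; beyond the scatter), although this single change alters both the nitrile and the chain length, and the two cannot be told apart here. The step of a 2.2-fold higher number from compound 2 to compound 4 (0.35 log units; beyond the scatter) shows that a six-membered ring alone does not secure a low number, since the aromatic ring of compound 4 falls behind even the smaller cyclobutyl ring of compound 2, and among these compounds only the non-aromatic six-membered ring of compound 1 gives the lowest number.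

No measurement shown explains why these groups rank as they do. Going by these compounds, it remains open whether a cyclopentyl or cycloheptyl ring, or a piperidine ring carrying an amine, would match cyclohexyl, and whether lengthening the chain on cyclohexyl would change the number as much as swapping the ring does.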